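Swapping chloro for methyl in an ecdysone receptor agonist

The compounds below may be only part of what the source reports. "The series", "measured", "known", "first", "only" and "open" are said of these compounds alone.

Three close relatives share one core: compound 1 `CC(C)(C)N(NC(=O)c1ccccc1Br)C(=O)c1ccccc1Cl`, compound 2 `Cc1ccccc1C(=O)NN(C(=O)c1ccccc1Cl)C(C)(C)C` and compound 3 `CC(C)(C)N(NC(=O)c1cccc(Cl)c1)C(=O)c1ccccc1Cl`. In an assay on cells for agonist activity at ecdysone receptor (Bombyx mori), read by a luciferase reporter, with a stated time of 24 h (a higher number here means that more compound is needed for the effect, a lower number that less compound is needed), compound 1 gives 316 nM, compound 2 gives 72.4 nM and compound 3 gives 155 nM. Compound 3 thus stands second highest of the three, with compound 1 a 2.0-fold lower number from compound 1 to compound 3 (0.31 log units; beyond the scatter) and compound 2 a 2.1-fold higher number from compound 2 to compound 3 (0.33 log units; beyond the scatter).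

The next compound, compound 4 `Cc1cccc(C(=O)NN(C(=O)c2ccccc2Cl)C(C)(C)C)c1`, is unmeasured. It differs from compound 3 by methyl in place of chloro on an aromatic carbon. Among the compounds with values here, only one measured step also trades a halogen for a methyl on this ring: a 4.4-fold lower number from compound 1 to compound 2 (0.64 log units; beyond the scatter). That change was made on a different ring position, so it is a loose guide; the other steps change the ring position itself and do not bear directly. A modest drop in this assay is therefore expected, smaller than the one seen before. The expected step is a 1.9-fold lower number from compound 3 to compound 4 (0.29 log units; within the scatter), giving an estimate for compound 4 of 80 nM, with a likely range from 35 nM to 180 nM.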

Compound 4, half-maximal effective concentration: 603 nM
Estimate against measurement, compound 4: 7.5-fold (0.88 log units) below; measured number above the stated range.
By their numbers in this assay, from the lowest: compound 2; then compound 3; then compounds 1 and 4 (each within the scatter of the next).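

In this assay, within the data shown here, the swap of methyl for chloro on this carbon goes the opposite way to the one earlier halogen-to-methyl swap: a 3.9-fold higher number from compound 3 to compound 4 (0.59 log units; beyond the scatter), against a 4.4-fold lower number from compound 1 to compound 2 (0.64 log units; beyond the scatter) at a different place on the ring. So a methyl cannot be treated as a stand-in for a halogen across this ring, and its place matters: with 3-methylphenyl in place of 2-methylphenyl, the step is an 8.3-fold higher number from compound 2 to compound 4 (0.92 log units; beyond the scatter), while a 1.9-fold higher number from compound 1 to compound 4 (0.28 log units; within the scatter) leaves those two compounds indistinguishable. Nothing available explains why the direction reverses.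

Going by these compounds, it remains open how other groups on this carbon, such as a methoxy, an amine or a carboxylic acid, would compare with chloro and methyl. On these data alone, whether the same reversal appears with a different group in place of the chloro on the second ring also remains unknown.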